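The source may report more compounds than this note shows. Statements on the series, on what has been measured and on what is new or still open speak of the compounds shown alone.

Working notes on the series, on an assay on isolated protein for inhibition of high affinity 3',5'-cyclic-AMP phosphodiesterase 7A (Homo sapiens), read by scintillation proximity assay and cAMP accumulation, with a stated time of 20 min, tested at 10 uM; on this read-out higher numbers stand for more inhibition at the one concentration tested (going by the name of the read-out) and lower numbers for less inhibition.

Of the compounds shown here, two have numbers so far. Compound 1, `COc1cc(C(=O)OCc2ccc(-c3ccc(Cl)cc3Cl)o2)cc(OC)c1OC`, gives 24.4% in this assay. Compound 2, `COc1cc(COC(=O)c2ccc(C)o2)cc(OC)c1OC`, gives -9.9% in this assay, the lowest of the two numbers; the nearest number, that of compound 1, lies higher by an amount beyond the usual scatter. Among the measured compounds shown here, compounds 1 and 2 differ in more than one place, so their two values are compared only as they stand, and no single step is drawn between them.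

Compound 3, `COc1cc(COC(=O)c2ccc(-c3ccccc3C(F)(F)F)o2)cc(OC)c1OC`, is not yet measured. It differs from compound 2 in one place: 2-(trifluoromethyl)phenyl in place of methyl on an aromatic carbon. The new group sits on an aromatic carbon of a five-membered aromatic ring with 1 oxygen, next to the ring oxygen.

For the measured compounds named here, with no step between measured compounds to lean on, the expectation for compound 3 rests on the two values alone. Going by the values given here, compound 1, the only compound carrying a six-membered aromatic ring on that position, gives 24.4%, so an upward step is expected in this assay. The step from compound 2 to compound 3 is expected to be a number 27.9 percentage points higher from compound 2 to compound 3 (beyond the scatter), beyond the scatter. Compound 3 is therefore expected to give 18%, within -2% to 40%.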

Compound 3, a percentage reported as inhibition, at one concentration (the size of the read-out at that concentration, not a potency): 54.9%
The estimate for compound 3 lay 36.9 percentage points below the measured number, and the stated range ends below it.
By their numbers in this assay, from the lowest: compound 2; then compound 1; then compound 3.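

In this assay, the position on an aromatic carbon of the five-membered aromatic ring with 1 oxygen, next to the ring oxygen, now has a step that can be read at one place: 2-(trifluoromethyl)phenyl in place of methyl gives a number 64.8 percentage points higher from compound 2 to compound 3 (beyond the scatter), a large change. The earlier pair differed in more than one place, so it could not show how strongly the number answers to this position alone; this exchange shows that the number moves strongly there when the methyl gives way to a group carrying one six-membered aromatic ring of carbon only. The compounds shown offer no measurement that explains the size of the step.

The compounds shown leave open how the step divides between the phenyl ring and its trifluoromethyl group, which a plain phenyl or a phenyl bearing a chlorine or a methoxy group in place of the trifluoromethyl could address. They also leave open whether 2-(trifluoromethyl)phenyl would bring a similar step on the core of compound 1.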